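The compounds below may be only part of what the source reports. "The series", "measured", "known", "first", "only" and "open" are said of these compounds alone.

Working notes on the series. Compound 1 `CCCCCN(CCCCC)C(=O)N1CCN(C(=O)N(c2ccccc2)c2ccccc2)C(C(=O)O)C1` is drawn with no configuration at its ring stereocentre and in an assay for inhibition of Type-2 angiotensin II receptor (Rattus norvegicus) (a higher number here means a weaker inhibitor, a lower number a stronger inhibitor), compound 1 gives 1.7 nM. Among the measured compounds shown here, compound 2 `CCCCCN(CCCCC)C(=O)N1CCN(C(=O)N(c2ccccc2)c2ccccc2)[C@@H](C(=O)O)C1`, the same compound drawn with the R configuration, gives in this assay 4.5 nM; that is the higher of the two numbers so far, with a 2.6-fold higher number from compound 1 to compound 2 (0.42 log units; beyond the scatter). The separation is read as a consequence of the fact that one of compounds 1 and 2 is drawn with a defined configuration and the other without, at the place where they differ; the form drawn without configuration holds both arrangements, and compound 2 alone is the weaker of them.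

Compound 3 `CCCCCN(CCCCC)C(=O)N1CCN(C(=O)N(c2ccccc2)c2ccccc2)[C@H](C(=O)O)C1` is the other arrangement: the two compounds have the same atoms and bonds and differ only in configuration as drawn: 1 of 1 stereo elements differ; a stereocentre at a saturated ring carbon is drawn R in compound 2 and S in compound 3. For the measured compounds named here, the one measured step bears on it directly. If compound 1 is a mixture and compound 2 its weaker half, then compound 3 must carry the stronger part, and a step is expected in this assay of a 4.1-fold lower number from compound 2 to compound 3 (0.61 log units; beyond the scatter), downward. Compound 3 is estimated at 1.1 nM in this assay, within 0.4 nM to 3 nM.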

Compound 3, half-maximal inhibitory concentration: 1.4 nM
The estimate for compound 3 lay 1.3-fold (0.10 log units) below the measured number; low and high end bracket the measured number.
By their numbers in this assay, from the lowest: compounds 3 and 1 (each within the scatter of the next); then compound 2.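

The opposite configuration at this ring carbon has now been measured: going from R to S gives a 3.2-fold lower number from compound 2 to compound 3 (0.51 log units; beyond the scatter) in this assay, so compound 3 is the stronger of the two defined arrangements. This separation is read as a consequence of a single difference: the fact that compounds 2 and 3 differ only in the configuration as drawn. Compound 3 also cannot be separated from the form drawn without configuration, with a 1.2-fold lower number from compound 1 to compound 3 (0.08 log units; within the scatter), so the earlier gap between compound 1 and compound 2 now has a defined S counterpart that stands level with compound 1.

Going by these compounds, the proportion of the two arrangements in compound 1 remains open. Also open, on these data alone, is whether a methyl ester or a primary amide in place of the carboxylic acid would keep the same order of S over R.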